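The source may report more compounds than this note shows. Statements on the series, on what has been measured and on what is new or still open speak of the compounds shown alone.

Compound 1, `COc1cc2c(cc1N1C[C@@H](C)N(C)[C@@H](C)C1)N(C(=O)c1ccc(-c3cccc(C)n3)c3ccccc13)CC2`, is measured in an assay on isolated protein for binding affinity to 5-hydroxytryptamine receptor 1B (Homo sapiens) (a lower number here means a stronger inhibitor, a higher number a weaker inhibitor), where compound 1 gives 3.16 nM. Compound 2, `COc1cc2c(cc1N1C[C@@H](C)N[C@@H](C)C1)N(C(=O)c1ccc(-c3cccc(C)n3)c3ccccc13)CC2`, differs from it by hydrogen in place of methyl on an amine nitrogen in a ring and gives 50.1 nM in this assay; that change brought a 16-fold higher number from compound 1 to compound 2 (1.20 log units; beyond the scatter). Compound 3, `COc1cc2c(cc1N1C[C@@H](C)N(C)[C@@H](C)C1)N(C(=O)c1ccc(-c3ccc(-c4noc(C)n4)cc3C)cc1)CC2`, carries a different core, and the difference between the two cores is not broken down here; in this assay compound 3 gives 5.01 nM, a value within the usual scatter of that of compound 1. Compound 4, `COc1cc2c(cc1N1C[C@@H](C)N[C@@H](C)C1)N(C(=O)c1ccc(-c3ccc(-c4noc(C)n4)cc3C)cc1)CC2`, has not been measured. It differs from compound 3 by hydrogen in place of methyl on an amine nitrogen in a ring, the same change, at the same place, as that from compound 1 to compound 2. Because the earlier change brought a 16-fold higher number from compound 1 to compound 2 (1.20 log units; beyond the scatter), the step from compound 3 to compound 4 is expected to be of a similar size, a 16-fold higher number from compound 3 to compound 4 (1.20 log units; beyond the scatter), though it rests on a single earlier pair. For compound 4 in this assay the value is thus estimated at 80 nM, expected to lie between 25 nM and 250 nM.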

Compound 4, inhibition constant: 3.16 nM
The estimate for compound 4 lay 25-fold (1.40 log units) above the measured number; measured number outside the range, below it.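

On the core of compound 3, the change from 3,4,5-trimethylpiperazin-1-yl to 3,5-dimethylpiperazin-1-yl gave a 1.6-fold lower number from compound 3 to compound 4 (0.20 log units; within the scatter) in this assay, so the large loss seen on the core of compound 1 did not reappear. Set side by side, the two steps do not agree: the same change on two cores in this assay, a 16-fold higher number (1.20 log units; beyond the scatter) from compound 1 to compound 2 and a 1.6-fold lower number (0.20 log units; within the scatter) from compound 3 to compound 4, 25-fold (1.40 log units) apart, beyond the scatter of two such steps

Within the data shown here, this shows that, for these two cores, the size of this step depends on the core it is made on, and a step read on one cannot simply be carried to the other; it does not show which feature of the cores decides the outcome, and each core supplies only a single pair. The compounds shown leave open which part of the core governs the step, and which of the two results a third core would follow. They also leave open how a larger group on the ring nitrogen, such as ethyl or acetyl, would behave on either core.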